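Working notes: halogen swap from compound 3 to compound 4

The source may report more compounds than this note shows. Statements on the series, on what has been measured and on what is new or still open speak of the compounds shown alone.

Among the measured compounds shown here, compound 3 `Clc1ccc(-c2csc(N/N=C/c3ccc(N4CCCC4)cc3)n2)c(Cl)c1` gives 103000 nM in an assay on isolated protein for inhibition of Amine oxidase [flavin-containing] A (Homo sapiens), read by fluorescence and Amplex Red, with a stated time of 30 min (a lower number here means a stronger inhibitor, a higher number a weaker inhibitor), the highest of the three numbers measured so far. Compound 2 `Brc1ccc(-c2csc(N/N=C/c3ccc(N4CCCC4)cc3)n2)cc1` gives 61300 nM, and compound 1 `C(=N/Nc1nc(-c2ccccc2)cs1)\c1ccc(N2CCCC2)cc1` gives 25600 nM. The separation is a 1.7-fold higher number from compound 2 to compound 3 (0.23 log units; within the scatter) and a 4.0-fold higher number from compound 1 to compound 3 (0.60 log units; beyond the scatter). Compound 4 `Fc1ccc(-c2csc(N/N=C/c3ccc(N4CCCC4)cc3)n2)c(F)c1` carries 2,4-difluorophenyl in place of 2,4-dichlorophenyl on an aromatic carbon. For the measured compounds named here, the steps that bear on this change are a 2.4-fold higher number from compound 1 to compound 2 (0.38 log units; beyond the scatter) and a 4.0-fold higher number from compound 1 to compound 3 (0.60 log units; beyond the scatter), each a halogenated ring replacing the plain one, and the small gap a 1.7-fold higher number from compound 2 to compound 3 (0.23 log units; within the scatter) between the two halogenated compounds. Exchanging one halogen pair for another is therefore expected to move the number only modestly, if at all, and the expected step is a 1.6-fold lower number from compound 3 to compound 4 (0.20 log units; within the scatter). For compound 4 the estimate in this assay is 65000 nM, within 25000 nM to 160000 nM.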

Compound 4, half-maximal inhibitory concentration: 15600 nM
For compound 4 the middle estimate is 4.2-fold (0.62 log units) above the measured one; measured number outside the range, below it.
By their numbers in this assay, from the lowest: compounds 4 and 1 (each within the scatter of the next); then compounds 2 and 3 (each within the scatter of the next).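

The identity of the halogen pair matters at this position, as the 2,4-difluorophenyl group reads far lower than 2,4-dichlorophenyl (a 6.6-fold lower number from compound 3 to compound 4 (0.82 log units; beyond the scatter)) and also lower than 4-bromophenyl (a 3.9-fold lower number from compound 2 to compound 4 (0.59 log units; beyond the scatter)). Halogenation of this ring therefore does not always raise the number: compounds 2 and 3 do, whereas compound 4 stays within the scatter of the plain phenyl compound (a 1.6-fold lower number from compound 1 to compound 4 (0.22 log units; within the scatter)). Nothing at hand explains the gap between the two halogen pairs.

As far as these compounds go, whether one fluorine alone gives the same reading remains open. So does the reading with a methoxy group or an amine on this ring.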